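A few compounds are considered here, and "the series" means these few. Any claim that something is new, unique, unknown or untested is made for them only; others in the source may bear on it.

Compound 1 `CCOC(=O)c1ccc(-c2nn(Cc3cccc(OC)c3)c3ccccc23)cc1` — in a functional assay on cells (Platelet, Homo sapiens) for inhibition (on this read-out higher numbers stand for weaker inhibition and lower numbers for stronger inhibition), compound 1 gives > 10000 nM, a limit of the assay.
Compound 2 `CNC(=O)c1ccc(-c2nn(Cc3ccccc3)c3ccccc23)cc1` — compound 2 gives > 10000 nM, again a limit.
Compound 3 `CCNC(=O)c1ccc(-c2nn(Cc3ccccc3)c3ccccc23)cc1` — compound 3 gives > 10000 nM, again a limit.

Compound 1 therefore stands at the limit of > 10000 nM in this assay, at which 3 of the 3 values shown sit, and nothing separates it from the other two measured compounds. Among the compounds with values here, the single one-place step that was measured, a step that the two limits leave unreadable from compound 2 to compound 3, cannot be read because the limit of > 10000 nM in this assay, at which 3 of the 3 values shown sit, bounds both of its ends. Compound 4 `CCOC(=O)c1ccc(-c2nn(-c3ccccc3)c3ccccc23)cc1` differs from compound 1 by phenyl in place of 3-methoxybenzyl on an aromatic nitrogen. Within the data shown here, no measured step bears on this change, so nothing in the data points toward a gain or a loss beyond the scatter. Compound 4 is accordingly expected to remain weak, with an estimated 20000 nM and a range from 5000 nM to 80000 nM. The expected step is a step that the limit leaves unreadable from compound 1 to compound 4.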

Compound 4, half-maximal inhibitory concentration: > 10000 nM
Compound 4 ended at the assay's limit (the forecaster's own chance of this, stated with the estimate: 85%); the middle value does not contradict the limit.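

No step can be read between compound 1 and compound 4, because both stand at the same limit: the limit of > 10000 nM in this assay, at which 4 of the 4 values shown sit. The compounds shown leave open which change to the shared core, if any, would give a readable value instead of a limit.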